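A Small Fluorinated Change to a Potent Amide

The source may hold more compounds than are shown below. What is called first, only, known or untested is meant among the compounds shown, and "the series" means these compounds.

Compound 1 `CCC(=O)NCc1ccc(NC(=O)[C@H]2C[C@@H]2c2cccnc2)cc1` gives 405 nM
Compound 2 `CCC(=O)N[C@@H](C)c1ccc(NC(=O)[C@H]2C[C@@H]2c2cccnc2)cc1` gives 5 nM
Compound 3 `CCC(=O)NC(C)(C)c1ccc(NC(=O)[C@H]2C[C@@H]2c2cccnc2)cc1` gives 832 nM

In a functional assay on A2780 cells (Homo sapiens) for antiproliferative activity, read by CellTiter-Glo, with a stated time of 4 days (on this read-out lower numbers stand for stronger inhibition and higher numbers for weaker inhibition), compound 2 has the lowest number of the three, and its steps to both others lie beyond the scatter. Compound 4 `C[C@H](NC(=O)CC(F)(F)F)c1ccc(NC(=O)[C@H]2C[C@@H]2c2cccnc2)cc1` differs from compound 2 in one place: trifluoromethyl in place of methyl on a saturated chain carbon bound to a carbonyl carbon. In other words, propanoyl becomes (2,2,2-trifluoroethyl)carbonyl.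

Among the measured compounds shown here, no measured compound changes this group, so no step speaks to it directly. The nearest evidence is an 81-fold lower number from compound 1 to compound 2 (1.91 log units; beyond the scatter) and a 170-fold higher number from compound 2 to compound 3 (2.22 log units; beyond the scatter). Both are large, but they concern a different carbon, the one bound to an amide-type nitrogen and an aromatic carbon. They show only that small edits can matter greatly in this set, which argues for a wide range. A small rise in this assay is therefore expected, possibly no larger than the scatter. The estimate means a 1.6-fold higher number from compound 2 to compound 4 (0.20 log units; within the scatter). Compound 4 is expected at 8 nM, with an estimated range of 2 nM to 40 nM.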

Compound 4, half-maximal inhibitory concentration: 5 nM
Estimate against measurement, compound 4: 1.6-fold (0.20 log units) above, within the range that was stated.
By their numbers in this assay, from the lowest: compounds 2 and 4 (each within the scatter of the next); then compound 1; then compound 3.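

In this assay, trifluoromethyl in place of methyl on a saturated chain carbon bound to a carbonyl carbon gives no change at the digits printed from compound 2 to compound 4 (within the scatter). Among the compounds shown here, this is the first direct reading at this place, and it shows that trifluoromethyl can stand where methyl stood, with the two compounds reading alike. The earlier large steps, such as an 81-fold lower number from compound 1 to compound 2 (1.91 log units; beyond the scatter), concerned a different carbon, so they did not show how this one would respond. Nothing measured here accounts for why the two compounds read alike.

From the compounds shown here alone, only these two groups have been compared at this place, so it remains open whether the same holds for very different ones. An amine, a carboxylic acid or a longer chain such as butyl could read quite differently in this assay.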